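Trading a Butyl Chain for Hydrogen in a Cell Tolerance Test

The source may hold more compounds than are shown below. What is called first, only, known or untested is meant among the compounds shown, and "the series" means these compounds.

Compound 1 `CCCCOc1ccc(C(=O)NNc2c(Br)cccc2Br)cc1` was examined in a toxicity assay on MDCK cells (Canis lupus familiaris) for cytotoxicity, read by CCK-8 assay, with a stated time of 48 h; a higher number here means that more compound is tolerated, a lower number that less compound is tolerated. There compound 1 gave only a limit rather than a number, > 100000 nM. Compound 2 `O=C(NNc1c(Br)cccc1Br)c1cccnc1` also gave only a limit in this assay, > 100000 nM. Compound 1 thus stands where every value shown stands, (the limit of > 100000 nM in this assay, at which 2 of the 2 values shown sit). Compound 3 `O=C(NNc1c(Br)cccc1Br)c1ccc(O)cc1` differs from compound 1 by hydrogen in place of butyl on an oxygen on an aromatic ring. Going by the values given here, with no measured step to lean on, nothing beyond the usual scatter is expected in this assay for this change, in either direction. Compound 3 is therefore expected near 150000 nM, within 50000 nM to 400000 nM. The expected step is a step that the limit leaves unreadable from compound 1 to compound 3.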

Compound 3, half-maximal cytotoxic concentration: > 100000 nM
Compound 3 ended at the assay's limit; the forecaster's own chance of this, stated with the estimate: 80%; the middle value lies beyond the limit too.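

Going by these compounds alone, compound 1 and compound 3 both give only a limit in this assay, so no step between them can be read: (the limit of > 100000 nM in this assay, at which 3 of the 3 values shown sit).

As far as these compounds go, whether butoxy to hydroxy changes cell tolerance at all, and what concentration of either compound would harm these cells, stays open.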